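Butyl chain on the quinoline core: effect of a methyl step

This account rests on a few compounds, and the source may have more. Where it says the series, first, only, none or still open, it means among the compounds named here.

Compound 1, `CCCCc1cc2ccccc2nc1-c1cc(-c2ccccc2)no1`; in a functional assay on COLO 205 cells (Homo sapiens) for inhibition, read by MTT assay, with a stated time of 24 h (a higher number here means a weaker inhibitor, a lower number a stronger inhibitor), compound 1 gives a limit of the assay, > 100000 nM.
Compound 2, `CCCCc1cc2ccccc2nc1-c1cc(-c2ccc(F)cc2)no1`; in this assay compound 2 gives 25300 nM.
Compound 3, `CCCc1cc2ccccc2nc1-c1cc(-c2ccc(C)cc2)no1`; in this assay compound 3 gives a limit of the assay, > 100000 nM.

Compound 3 therefore stands only at a limit in this assay; no number is known for it, and the same holds for (the limit of > 100000 nM in this assay, at which 2 of the 3 values shown sit). Compound 4, `CCCCc1cc2ccccc2nc1-c1cc(-c2ccc(C)cc2)no1`, differs from compound 3 by methyl in place of hydrogen on a saturated chain carbon, three bonds along the chain from an aromatic carbon, a change that reads as propyl to butyl on the saturated chain.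

Only one measured step exists among the shown compounds, an at least 3.9-fold lower number from compound 1 to compound 2 (0.59 log units; beyond the scatter), and it concerns fluoro in place of hydrogen on an aromatic carbon, not the chain. No measured step bears on lengthening the chain by one carbon, so nothing among the shown compounds indicates a step in this assay beyond the scatter in either direction for this change. With compound 3 at a limit, compound 4 is expected to sit at or near that limit as well, the expected step being a number no higher from compound 3 to compound 4 (the limit leaves the size open). The estimate for compound 4 in this assay is 100000 nM, with a range from 30000 nM to 300000 nM.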

Compound 4, half-maximal inhibitory concentration: > 100000 nM
Compound 4 was reported as a limit (the forecaster's own chance of this, stated with the estimate: 70%); the middle value lies on the limit itself.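

Lengthening the chain from propyl to butyl does not bring the methyl-bearing compound to a readable number in this assay: compound 4 stands at a limit of the assay, as compound 3 does. The one readable new step concerns the other end of the molecule, where methyl in place of fluoro on an aromatic carbon, with the butyl chain held constant, gives an at least 3.9-fold higher number from compound 2 to compound 4 (0.59 log units; beyond the scatter); among the butyl compounds shown, the fluoro compound alone gives a number, while the hydrogen and methyl compounds do not. The steps that start from compound 1 and compound 3 and end at compound 4 cannot be read, because each joins two limits: the limit of > 100000 nM in this assay, at which 3 of the 4 values shown sit.

Going by these compounds, how far these limit compounds lie from one another therefore stays open, and so does any real effect of the propyl to butyl change. Also open, on these data alone, is whether a chloro or methoxy group in place of the fluoro, or a pentyl chain in place of the butyl chain, would give a number in this assay.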